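The source may report more compounds than this note shows. Statements on the series, on what has been measured and on what is new or still open speak of the compounds shown alone.

The study concerns three measured compounds and one that awaits its number. Compound 1, `CO[C@]1(c2cnc(Sc3ccc(/C(C)=N/O)cc3)s2)CCO[C@@H](C)C1`, is the most potent of the numbered compounds in a functional assay (blood) for inhibition, with Homo sapiens as the target (on this read-out lower numbers stand for stronger inhibition and higher numbers for weaker inhibition), where compound 1 gives 40 nM. Compound 2, `CCOC(=O)CO/N=C(\C)c1ccc(Sc2cc(F)cc(C3CCOCC3)c2)cc1`, carries the highest of the two plain numbers: in this assay compound 2 gives 610 nM, and its nearest neighbour is compound 1, whose number lies well below it, a gap beyond the scatter. Compound 3, `C/C(=N\O)c1ccccc1Sc1cc(F)cc(C2CCOCC2)c1`, reaches only the limit of the assay: in this assay compound 3 gives > 10000 nM, which is a limit and not a number. Of the three values shown, one sits at this limit, (the limit of > 10000 nM in this assay, at which 1 of the 3 values shown sits).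

The step under study leads from compound 2 to compound 4, `C/C(=N\O)c1ccc(Sc2cc(F)cc(C3CCOCC3)c2)cc1`. The two differ in one place: hydrogen in place of (ethoxycarbonyl)methyl on an oxygen. For the measured compounds named here, no directly comparable pair among the measured compounds shows what such a change does on this core. Compound 1, which also carries the free hydroxy on the double-bonded nitrogen, gives 40 nM in this assay. Compound 3, which carries it too, gives only a limit in this assay. The expected step, a 3.1-fold lower number from compound 2 to compound 4 (0.48 log units; beyond the scatter), is a moderate move toward stronger inhibition. For compound 4 the estimate is 200 nM, within a range of 40 nM to 1000 nM.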

Compound 4, half-maximal inhibitory concentration: 80 nM
Compound 4: the middle estimate sits 2.5-fold (0.40 log units) above what was measured; low and high end bracket the measured number.
By their numbers in this assay, from the lowest: compounds 1 and 4 (each within the scatter of the next); then compound 2. At a limit, above all of these: compound 3.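

On the shared core of compound 2 and compound 4, hydrogen in place of (ethoxycarbonyl)methyl on an oxygen whose other neighbour is the double-bonded nitrogen gives, in this assay, a 7.6-fold lower number from compound 2 to compound 4 (0.88 log units; beyond the scatter). For the compounds shown here, this is the first direct reading of the change: the earlier compounds with the free hydroxy, compound 1 and compound 3, offered no matched partner, so they could not show what the (ethoxycarbonyl)methyl group costs or gains at this place. The step shows that, in this one pair, the group on this oxygen affects the number by more than the usual scatter and that the hydroxy form is the stronger of the two, but nothing shown gives a cause for the step.

The compounds shown leave open whether the whole chain matters or only part of it, as the outcome with a methyl group, a longer alkyl chain or a carboxymethyl group on the same oxygen remains unknown. Going by these compounds alone, also open is whether the same change would have a similar effect on the core of compound 1, as only one matched pair is available.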